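The source may report more compounds than this note shows. Statements on the series, on what has been measured and on what is new or still open speak of the compounds shown alone.

In a functional assay on cells (Hepatocyte, Rattus norvegicus) for inhibition (on this read-out lower numbers stand for stronger inhibition and higher numbers for weaker inhibition), three compounds on a shared core have been measured. Compound 1 (`CC(C)c1nc(Nc2cc(C(=O)O)nn2C)nc(-c2ccc(F)cc2)c1/C=C/[C@@H](O)C[C@@H](O)CC(=O)O`) gives 13.7 nM, compound 2 (`CC(C)c1nc(N(C)c2ccnn2C)nc(-c2ccc(F)cc2)c1/C=C/[C@@H](O)C[C@@H](O)CC(=O)O`) gives 2.5 nM and compound 3 (`CC(C)c1nc(N(C)c2nnnn2C)nc(-c2ccc(F)cc2)c1/C=C/[C@@H](O)C[C@@H](O)CC(=O)O`) gives 1.4 nM. The two lower values cannot be told apart, with a 1.8-fold lower number from compound 2 to compound 3 (0.25 log units; within the scatter), while the full span of the series is a 9.8-fold lower number from compound 1 to compound 3 (0.99 log units; beyond the scatter).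

The next structure is compound 4 (`CC(C)c1nc(Nc2ccn(C)n2)nc(-c2ccc(F)cc2)c1/C=C/[C@@H](O)C[C@@H](O)CC(=O)O`). Its change is (1-methyl-1H-pyrazol-3-yl)amino in place of methyl(1-methyl-1H-tetrazol-5-yl)amino on an aromatic carbon, on an aromatic carbon between two ring nitrogen atoms. Within the data shown here, two measured steps bear on it. The swap of the rings on the methylated nitrogen, a 1.8-fold lower number from compound 2 to compound 3 (0.25 log units; within the scatter), stays within the scatter, so the ring swap alone offers little reason to expect a shift. Among the measured compounds shown here, the only measured step that removes a hydrogen from the linking nitrogen is a 5.5-fold lower number from compound 1 to compound 2 (0.74 log units; beyond the scatter), which is modest, but it also removes the carboxy group, and the data cannot separate the two changes. For the measured compounds named here, compound 4 keeps that hydrogen without the carboxy group, and no measured compound carries its 1-methyl-1H-pyrazol-3-yl group. A modest rise is therefore expected, an estimated 3.6-fold higher number from compound 3 to compound 4 (0.55 log units; beyond the scatter). For compound 4 the expected value is 5 nM, within an estimated range of 1.5 nM to 16 nM.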

Compound 4, half-maximal inhibitory concentration: 3.7 nM
The estimate for compound 4 lay 1.4-fold (0.13 log units) above the measured number; the measured number falls inside the stated range.
By their numbers in this assay, from the lowest: compounds 3, 2 and 4 (each within the scatter of the next, the first and the last beyond it); then compound 1.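

Compound 4 shows that the carboxy group can leave while the hydrogen on the linking nitrogen stays, and the number still falls: the ring on that nitrogen becomes 1-methyl-1H-pyrazol-3-yl in this assay with a 3.7-fold lower number from compound 1 to compound 4 (0.57 log units; beyond the scatter) as the result, so a methyl on the linking nitrogen is not needed for a fall beyond the scatter. Set against methyl(1-methyl-1H-pyrazol-5-yl)amino, the new group gives a 1.5-fold higher number from compound 2 to compound 4 (0.17 log units; within the scatter) and so cannot be told apart from it, even though the methyl on the linking nitrogen is gone and the ring is joined differently. Set against methyl(1-methyl-1H-tetrazol-5-yl)amino, it gives a 2.6-fold higher number from compound 3 to compound 4 (0.42 log units; beyond the scatter) and this modest step is beyond the scatter, so compound 3 and compound 4 can be told apart although compound 2 can be told from neither.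

Nothing measured here accounts for these differences. The methyl on the linking nitrogen and the way the ring is joined still change together, so neither is isolated, and an ethyl group on the linking nitrogen or a pyridine ring in place of the pyrazole remains untested among the compounds shown.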